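Swapping an aryl amide for a pyridyl amide

The source may report more compounds than this note shows. Statements on the series, on what has been measured and on what is new or still open speak of the compounds shown alone.

Compound 1 `Cc1ccc(NC(=O)C2CCN(C/C=C/c3ccccc3)CC2)cc1` has the lowest of the two numbers in a functional assay on HepG2 cells (Homo sapiens) for inhibition, read by MTT assay, with a stated time of 72 h (on this read-out lower numbers stand for stronger inhibition and higher numbers for weaker inhibition), where compound 1 gives 33900 nM. Its nearest neighbour is compound 2 `O=C(Nc1cccc(F)c1)C1CCN(C/C=C/c2ccccc2)CC1`, which in this assay gives 51100 nM; the step of a 1.5-fold higher number from compound 1 to compound 2 (0.18 log units; within the scatter) lies within the scatter. Compound 3 `O=C(Nc1ccccn1)C1CCN(C/C=C/c2ccccc2)CC1` is not yet measured and differs from compound 1 as follows: pyridin-2-yl in place of 4-methylphenyl on an amide-type nitrogen. Going by the values given here, the only measured step, from compound 1 to compound 2, changed the same aryl group and moved the number little, so for compound 3 a step of about a 1.3-fold higher number from compound 1 to compound 3 (0.12 log units; within the scatter) is expected, not beyond the scatter. Compound 3 is therefore estimated at 45000 nM, likely between 15000 nM and 130000 nM.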

Compound 3, half-maximal inhibitory concentration: 51100 nM
Compound 3: the middle estimate sits 1.1-fold (0.06 log units) below what was measured; low and high end bracket the measured number.
By their numbers in this assay, from the lowest: compounds 1, 2 and 3 (each within the scatter of the next).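

In this assay, pyridin-2-yl on the amide-type nitrogen brings a ring nitrogen and a hydrogen-bond acceptor, yet the readout stays within the scatter against 4-methylphenyl (a 1.5-fold higher number from compound 1 to compound 3 (0.18 log units; within the scatter)) and against 3-fluorophenyl (no change at the digits printed from compound 2 to compound 3 (within the scatter)). This position has therefore now carried an aromatic ring with a hetero atom as well as two of carbon only, with no step beyond the scatter. No supporting data bear on this result.

Going by these compounds, whether a non-aromatic group here, such as cyclohexyl, would give a step beyond the scatter remains open. So does the effect of an amine or a carboxylic acid on the aromatic ring.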